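This account rests on a few compounds, and the source may have more. Where it says the series, first, only, none or still open, it means among the compounds named here.

In an ADME assay on Caco-2 cells (Homo sapiens) for permeability, read by LC-MS, with a stated time of 2 h, at pH 7.4, tested at 10 uM (on this read-out lower numbers stand for lower permeability and higher numbers for higher permeability), compound 3 `C[C@@H]1Cn2c(nnc2C(F)(F)F)CN1C(=O)c1cccc(C(F)(F)c2n[nH]c(=O)c3ccccc23)c1` gives 7.9 10^-6 cm/s and compound 2 `C[C@H]1Cn2c(nnc2C(F)(F)F)CN1C(=O)c1cccc(C(F)(F)c2n[nH]c(=O)c3ccccc23)c1` gives 6.7 10^-6 cm/s and the two lie within the scatter of each other. Compound 1 `O=C(c1cccc(C(F)(F)c2n[nH]c(=O)c3c2CCCC3)c1)N1CCn2c(nnc2C(F)(F)F)C1` gives 1.3 10^-6 cm/s and stands beyond the scatter from compound 3, on the low side.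

The next compound, compound 4 `O=C(c1cccc(C(F)(F)c2n[nH]c(=O)c3ccccc23)c1)N1CCn2c(nnc2C(F)(F)F)C1`, comes from compound 3 through a single change hydrogen in place of methyl on a saturated ring carbon in which hydrogen takes the place of methyl on a saturated ring carbon. Among the compounds with values here, the one measured step at that carbon is a 1.2-fold higher number from compound 2 to compound 3 (0.07 log units; within the scatter) and it stays within the scatter. Within the data shown here, both of its compounds keep the methyl, as the fact that compounds 2 and 3 differ only in the configuration as drawn makes clear, so no measured step shows what losing the methyl does.

The expectation therefore rests on a small structural change and on how close compound 2 and compound 3 lie. No step beyond the scatter is expected in this assay for this change, although compound 1 at 1.3 10^-6 cm/s keeps the low side of the range open. The estimated step is a 1.4-fold lower number from compound 3 to compound 4 (0.16 log units; within the scatter) and it is expected to stay within the scatter. For compound 4 the estimated value is 5.5 10^-6 cm/s with an expected range from 2.5 10^-6 cm/s to 11 10^-6 cm/s on this read-out.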

Compound 4, apparent permeability: 5.7 10^-6 cm/s
Compound 4: the middle estimate sits 1.0-fold (0.02 log units) below what was measured; low and high end bracket the measured number.
By their numbers in this assay, from the lowest: compound 1; then compounds 4, 2 and 3 (each within the scatter of the next).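

In this assay, the effect of losing the methyl can now be read directly: hydrogen in place of methyl on this saturated ring carbon gives a 1.4-fold lower number from compound 3 to compound 4 (0.14 log units; within the scatter) and a 1.2-fold lower number from compound 2 to compound 4 (0.07 log units; within the scatter), so the compound without the methyl stands apart from neither methyl-bearing form. Within the data shown here, the earlier compounds could not show this, since the only step at this carbon compared two methyl-bearing forms: the fact that compounds 2 and 3 differ only in the configuration as drawn. Among these compounds, compound 4 also gives compound 1 a partner that lacks the methyl as well, and a 4.4-fold higher number from compound 1 to compound 4 (0.64 log units; beyond the scatter) is the one new step beyond the scatter, with a six-membered aromatic ring of carbon only in place of a six-membered non-aromatic ring of carbon only, on the saturated chain carbon bound to an aromatic carbon and two fluorine atoms.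

On these data alone, it remains open whether a larger group on the saturated ring carbon, such as an ethyl chain, a hydroxymethyl group or an amine, would also stay within the scatter of compound 4. The numbers also leave open whether the step from compound 1 to compound 4 would keep its size with a methyl on the saturated ring carbon of both partners.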